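Lengthening the hydroxyalkyl chain on a shared core

A few compounds are considered here, and "the series" means these few. Any claim that something is new, unique, unknown or untested is made for them only; others in the source may bear on it.

Of the compounds shown here, three on a shared core have been measured in a physicochemical assay for solubility, read by HPLC, in phosphate buffer, at pH 6.5; on this read-out higher numbers stand for higher solubility and lower numbers for lower solubility. Compound 1 `OCCCCNc1nnc(-c2ccc(F)c(F)c2Nc2ccc(I)cc2F)o1` carries a 4-hydroxybutyl chain; in this assay compound 1 returns only a limit, < 3 ug/mL. Compound 2 `CNCCNc1nnc(-c2ccc(F)c(F)c2Nc2ccc(I)cc2F)o1` carries a methylamino where compound 1 carries a 2-hydroxyethyl; in this assay compound 2 gives 6.7 ug/mL. Compound 3 `OCCNc1nnc(-c2ccc(F)c(F)c2Nc2ccc(I)cc2F)o1` carries a 2-hydroxyethyl chain on the ring nitrogen; in this assay compound 3 likewise returns only a limit, < 3 ug/mL. Among the steps, an at least 2.2-fold higher number from compound 1 to compound 2 (0.34 log units; beyond the scatter), and an at least 2.2-fold lower number from compound 2 to compound 3 (0.34 log units; beyond the scatter). The remaining step is blind: a step that the two limits leave unreadable from compound 1 to compound 3, because both values sit at the limit of < 3 ug/mL in this assay, at which 2 of the 3 values shown sit. Compound 3 therefore stands at the floor of what this assay can report, alongside compound 1.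

Compound 4 `OCCCCCNc1nnc(-c2ccc(F)c(F)c2Nc2ccc(I)cc2F)o1` differs from compound 3 by 3-hydroxypropyl in place of hydroxy on a saturated chain carbon, two bonds along the chain from a nitrogen on an aromatic ring, so that the (2-hydroxyethyl)amino becomes a (5-hydroxypentyl)amino. Within the data shown here, the only measured step of the same kind, the one from compound 1 to compound 3, cannot be read, and compound 1, with its 4-hydroxybutyl chain, already sits at the limit. No step beyond the scatter is expected, and a further limit is the most likely outcome. Compound 4 is estimated at 2 ug/mL, between 0.8 ug/mL and 5 ug/mL. The expected step is a step that the limit leaves unreadable from compound 3 to compound 4.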

Compound 4, solubility: < 3 ug/mL
Compound 4: only a limit was reported; the forecaster's own chance of this, stated with the estimate: 70%; the middle value lies beyond the limit too.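

In this assay compound 4 returns only a limit, < 3 ug/mL. The steps from compound 3 to compound 4 and from compound 1 to compound 4 cannot be read, because the values at both ends of each sit at the floor of the read-out: the limit of < 3 ug/mL in this assay, at which 3 of the 4 values shown sit.

Among these compounds, the one readable step is an at least 2.2-fold lower number from compound 2 to compound 4 (0.34 log units; beyond the scatter), so the 5-hydroxypentyl chain, like the 2-hydroxyethyl and 4-hydroxybutyl chains before it, leaves the hydroxy-ended series without a measured number, and compound 2, with its methylamino, is still the only compound of the four that gives one.

On these data alone, whether chain length changes solubility at all among compound 1, compound 3 and compound 4 stays unknown, since any differences among them would lie under the limit. Also open, as far as these compounds go, is whether the gain seen with the methylamino of compound 2 belongs to an amine at the chain end more generally, and whether a dimethylamino group or a carboxylic acid in that place would lift the value further.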